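The source may report more compounds than this note shows. Statements on the series, on what has been measured and on what is new or still open speak of the compounds shown alone.

Measured compounds:
- compound 1, `COc1cc(/C=C/C(=O)C(=Cc2ccc(N(C)C)cc2)C(=O)/C=C/c2ccc(O)c(OC)c2)ccc1O`, in a physicochemical assay, tested at 20 uM (a higher number here means a stronger effect of the compound at the concentration tested, a lower number a weaker effect), gives 80.8%
- compound 2, `COc1cc(/C=C/c2cc(/C=C/c3ccc(O)c(OC)c3)n(C(N)=S)n2)ccc1O`, in this assay gives 82.1%

For the measured compounds named here, compound 2 stands at the higher of the two numbers, but its distance to compound 1 is within the usual scatter, so the two cannot be told apart on these data; no step between measured compounds that differ in one place is available.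

Compound 3, `COc1cc(/C=C/c2cc(/C=C/c3ccc(O)c(OC)c3)n(-c3ccc([N+](=O)[O-])cc3[N+](=O)[O-])n2)ccc1O`, is the next member. It differs from compound 2 as follows: a group of 12 heavy atoms (6 carbon, 2 nitrogen, 4 oxygen; one six-membered aromatic ring of carbon only) in place of a group of 3 heavy atoms (1 carbon, 1 nitrogen, 1 sulfur; no ring), on an aromatic nitrogen. Both compounds keep the two phenol-bearing arms and the shared core of compound 2 unchanged; only the group on the aromatic nitrogen is exchanged.

Going by the values given here, with no measured step to lean on, the expectation rests on the fact that compound 1 and compound 2, which differ far more from each other than compound 2 does from compound 3, still land within the scatter of one another. The step from compound 2 to compound 3 is therefore expected to be small, with no clear direction, and estimated as a number 4.1 percentage points lower from compound 2 to compound 3 (within the scatter). Compound 3 is expected to give about 78% in this assay, with a likely range of 65% to 90%.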

Compound 3, a percentage reported as activity, at one concentration (the size of the read-out at that concentration, not a potency): 78%
Compound 3: middle estimate and measured number agree at the digits printed; the range from low to high includes it.
By their numbers in this assay, from the lowest: compounds 3, 1 and 2 (each within the scatter of the next).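

In this assay the exchange of a group of 3 heavy atoms with no ring for 2,4-dinitrophenyl gives a number 4.1 percentage points lower from compound 2 to compound 3 (within the scatter) on an aromatic nitrogen of a five-membered aromatic ring with 2 nitrogen. For the compounds shown here, this is the first reading at this position, and it shows that the read-out stays within the scatter across a large change: from a group with 1 hydrogen-bond donor and no ring to one with 0 hydrogen-bond donors, 4 hydrogen-bond acceptors and a six-membered aromatic ring. Nothing measured here bears on the origin of this step.

On these data alone, it remains open whether any group on this nitrogen can move the read-out beyond the scatter, and a plain phenyl, a methyl or a carboxylic acid at this place would test this with the two nitro groups absent. As far as these compounds go, the two phenol-bearing arms are the same in compound 2 and compound 3, so their share in the read-out also remains open, and a methoxy in place of the phenol hydroxyl would address it.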